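This account rests on a few compounds, and the source may have more. Where it says the series, first, only, none or still open, it means among the compounds named here.

Measured in a functional assay on HepG2 cells (Homo sapiens) for antiproliferative activity, read by sulforhodamine B assay, with a stated time of 48 h; on this read-out higher numbers stand for weaker inhibition and lower numbers for stronger inhibition:
Compound 1 `COc1ccc(OC)c(/C=C/C(=O)/C=C(O)/C=C/c2cc(OC)ccc2OC)c1`: 5560 nM
Compound 2 `COc1ccc(C=C(C(=O)/C=C/c2cccc(OC)c2OC)C(=O)/C=C/c2cccc(OC)c2OC)cc1OC`: 200 nM

Of these two compounds, compound 2 has the lower number and so the stronger inhibition, and its gap to compound 1 lies beyond the usual scatter. Compound 3 `COc1cc(C=C(C(=O)/C=C/c2cccc(OC)c2OC)C(=O)/C=C/c2cccc(OC)c2OC)cc(Br)c1O` has not yet been measured. It differs from compound 2 in one place: 3-bromo-4-hydroxy-5-methoxyphenyl in place of 3,4-dimethoxyphenyl on a double-bonded chain carbon bound to a double-bonded chain carbon. This puts 3-bromo-4-hydroxy-5-methoxyphenyl in place of 3,4-dimethoxyphenyl on a double-bonded chain carbon bound to a double-bonded chain carbon.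

For the measured compounds named here, no measured pair here differs in just one place, so the data do not show directly what such a change does. The rest of the structure is kept, so the expectation starts from compound 2 at 200 nM. A small move toward a higher number is expected, not beyond the scatter. The estimated step is a 1.4-fold higher number from compound 2 to compound 3 (0.15 log units; within the scatter). For compound 3 the estimate is 280 nM, with an expected range from 80 nM to 1000 nM.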

Compound 3, half-maximal inhibitory concentration: 240 nM
The estimate for compound 3 lay 1.2-fold (0.07 log units) above the measured number, within the range that was stated.
By their numbers in this assay, from the lowest: compounds 2 and 3 (each within the scatter of the next); then compound 1.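

For the compounds shown here, this is the first pair in the set that differs in just one place. In this assay, putting 3-bromo-4-hydroxy-5-methoxyphenyl in place of 3,4-dimethoxyphenyl on a double-bonded chain carbon bound to a double-bonded chain carbon gives a 1.2-fold higher number from compound 2 to compound 3 (0.08 log units; within the scatter), so this position takes a bromine and a hydrogen-bond donor with no change that can be told from the scatter. No measurement of any property of these two groups bears on this result.

Going by these compounds, the entering group brings its bromine and its hydroxy in a single step, so what either does alone stays unknown. On these data alone, whether a carboxylic acid or a dimethylamino group on the ring at this position would also stay within the scatter of compound 2 remains open.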